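The source may hold more compounds than are shown below. What is called first, only, known or untested is meant among the compounds shown, and "the series" means these compounds.

Of the compounds shown here, three built on one shared core have been measured in a functional assay on MT4 cells (Homo sapiens) for antiproliferative activity, read by MTT assay, with a stated time of 96 h; on this read-out higher numbers stand for an effect only at larger amounts of compound and lower numbers for an effect already at smaller amounts. Compound 1 `N#C/C(=C\c1c(-c2ccccc2)[nH]c2ccccc12)C(=O)N1CCCCC1` gives 9600 nM in this assay. Compound 2 `N#C/C(=C\c1c(-c2ccccc2)[nH]c2ccccc12)C(=O)c1cccs1` gives 400 nM, and compound 3 `N#C/C(=C\c1c(-c2ccccc2)[nH]c2ccccc12)S(=O)(=O)c1ccccc1` gives 400 nM. Compound 3 thus stands level with compound 2, the two together at the lowest numbers of the three, with compound 1 far away. The steps behind this are a 24-fold lower number from compound 1 to compound 2 (1.38 log units; beyond the scatter) and a 24-fold lower number from compound 1 to compound 3 (1.38 log units; beyond the scatter), whereas no change at the digits printed from compound 2 to compound 3 (within the scatter).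

Compound 4 `COCCOC(=O)/C(C#N)=C/c1c(-c2ccccc2)[nH]c2ccccc12` differs from compound 3 in one place: (2-methoxyethoxy)carbonyl in place of phenylsulfonyl on a double-bonded chain carbon bound to a double-bonded chain carbon and a triple-bonded carbon. For the measured compounds named here, none of the measured steps exchanges an aryl-linked group for an ester, so they bear on this change only indirectly: the two large steps show that the group on this chain carbon can move the number a great deal, while the third step shows two quite different groups giving the same result. A moderate rise, short of compound 1, seems the most reasonable expectation. The expected step is a 3.8-fold higher number from compound 3 to compound 4 (0.57 log units; beyond the scatter). Compound 4 is expected to give about 1500 nM in this assay, within a range from 400 nM to 6000 nM.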

Compound 4, half-maximal effective concentration: 1200 nM
The estimate for compound 4 lay 1.3-fold (0.10 log units) above the measured number, within the range that was stated.
By their numbers in this assay, from the lowest: compounds 2 and 3 (each within the scatter of the next); then compound 4; then compound 1.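

In this assay, (2-methoxyethoxy)carbonyl on this chain carbon gives a level of its own, with a 3.0-fold higher number from compound 3 to compound 4 (0.48 log units; beyond the scatter) and a 3.0-fold higher number from compound 2 to compound 4 (0.48 log units; beyond the scatter), but also an 8.0-fold lower number from compound 1 to compound 4 (0.90 log units; beyond the scatter). For the compounds shown here, the earlier compounds showed only one high number and one shared low number, whereas this position now shows an intermediate level as well. Compounds 1, 2 and 4 all keep a carbonyl here, so the carbonyl alone does not set the number, and the group on that carbonyl carbon matters; a ring in that group does not decide the matter either, since compound 4 has none yet its number is lower than that of compound 1, which has one.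

Nothing available explains this order. On these data alone, it also remains open where a carboxylic acid or a simple methyl ester would fall at this position.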